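The source may report more compounds than this note shows. Statements on the series, on what has been measured and on what is new or still open speak of the compounds shown alone.

Compound 1 `COc1cc(C(=O)c2sc(-c3cccs3)cc2N)cc(OC)c1OC` gives 9.4 nM in a functional assay on CCRF-CEM cells (Homo sapiens) for antiproliferative activity (a lower number here means a stronger inhibitor, a higher number a weaker inhibitor), the lowest of the three numbers measured. Compound 2 `COc1cc(C(=O)c2sc(-c3ccc(Cl)c(Cl)c3)cc2N)cc(OC)c1OC` gives 290 nM in this assay, and compound 3 `COc1cc(C(=O)c2sc(-c3ccc(C(F)(F)F)cc3)cc2N)cc(OC)c1OC` gives 270 nM. Compound 4 `COc1cc(C(=O)c2sc(-c3cccc([N+](=O)[O-])c3)cc2N)cc(OC)c1OC` differs from compound 1 in one place: 3-nitrophenyl in place of thiophen-2-yl on an aromatic carbon. Within the data shown here, two measured steps bear on this one, since each also puts a substituted phenyl in place of thiophen-2-yl at the same position: a 31-fold higher number from compound 1 to compound 2 (1.49 log units; beyond the scatter) and a 29-fold higher number from compound 1 to compound 3 (1.46 log units; beyond the scatter), both large and both toward weaker inhibition. A step of similar direction and size is therefore expected here, a 27-fold higher number from compound 1 to compound 4 (1.42 log units; beyond the scatter). For compound 4 the expected value in this assay is 250 nM, with a range from 80 nM to 800 nM.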

Compound 4, half-maximal inhibitory concentration: 5.9 nM
The estimate for compound 4 lay 42-fold (1.63 log units) above the measured number, outside the stated range (below it).
By their numbers in this assay, from the lowest: compounds 4 and 1 (each within the scatter of the next); then compounds 3 and 2 (each within the scatter of the next).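

In this assay, a phenyl ring at this position need not cost activity: a 1.6-fold lower number from compound 1 to compound 4 (0.20 log units; within the scatter), so the loss seen with compound 2 and compound 3 does not come with every substituted phenyl. The substituents on the ring separate these compounds sharply, with a 46-fold lower number from compound 3 to compound 4 (1.66 log units; beyond the scatter) and a 49-fold lower number from compound 2 to compound 4 (1.69 log units; beyond the scatter). Nothing available explains this difference.

On these data alone, whether the result belongs to the nitro group itself or to where it sits on the ring remains open. A 4-nitrophenyl or a 3-aminophenyl group would help separate the two.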